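The compounds below may be only part of what the source reports. "The series", "measured", "known", "first", "only" and "open" are said of these compounds alone.

Working notes on the series in a functional assay on PC-3 cells (Homo sapiens) for cytotoxicity, read by MTT assay, with a stated time of 72 h; a lower number here means a stronger inhibitor, a higher number a weaker inhibitor. Compound 1 `O=C(/C=C/c1cccc(Cl)c1Cl)Nc1cc2c(Nc3ccc(F)c(Cl)c3)ncnc2cc1O[C@H]1CCOC1` gives 27500 nM. Going by the values given here, compound 2 `COc1ccc(/C=C/C(=O)Nc2cc3c(Nc4ccc(F)c(Cl)c4)ncnc3cc2O[C@H]2CCOC2)c(OC)c1` gives 2760 nM, the lower of the two numbers so far. Among the compounds with values here, the only measured step, a 10-fold lower number from compound 1 to compound 2 (1.00 log units; beyond the scatter), is modest but beyond the scatter, and it brought in the 2,4-dimethoxyphenyl group. Compound 3 `COc1cc(/C=C/C(=O)Nc2cc3c(Nc4ccc(F)c(Cl)c4)ncnc3cc2O[C@H]2CCOC2)cc(OC)c1OC` is not yet measured and changes the same place, on a double-bonded chain carbon bound to a double-bonded chain carbon: 3,4,5-trimethoxyphenyl in place of 2,4-dimethoxyphenyl on a double-bonded chain carbon bound to a double-bonded chain carbon. The measured step shows that this place can move the number, but it started from a 2,3-dichlorophenyl group, so it gives no direction for this exchange. No step beyond the scatter is therefore expected, and the estimated change is a 1.4-fold higher number from compound 2 to compound 3 (0.16 log units; within the scatter). Within the data shown here, the range stays wide because a 10-fold lower number from compound 1 to compound 2 (1.00 log units; beyond the scatter) is the only guide. For compound 3 the estimate is 4000 nM, with an expected range of 1200 nM to 15000 nM.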

Compound 3, half-maximal inhibitory concentration: 20500 nM
Compound 3: the middle estimate sits 5.1-fold (0.71 log units) below what was measured, outside the stated range (above it).
By their numbers in this assay, from the lowest: compound 2; then compounds 3 and 1 (each within the scatter of the next).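

In this assay, the exchange of 2,4-dimethoxyphenyl for 3,4,5-trimethoxyphenyl on a double-bonded chain carbon bound to a double-bonded chain carbon gives a 7.4-fold higher number from compound 2 to compound 3 (0.87 log units; beyond the scatter) and so lies beyond the scatter: this place separates two methoxy-bearing groups, not only a dichlorophenyl group from a dimethoxyphenyl group. The other new step, a 1.3-fold lower number from compound 1 to compound 3 (0.13 log units; within the scatter) and thus within the scatter, leaves 3,4,5-trimethoxyphenyl and 2,3-dichlorophenyl indistinguishable, so methoxy groups as such do not go with the lower number, and compound 3 goes against any such reading. No measurement bears on the reason for this difference.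

Compound 3 changes both the number of methoxy groups and their places, so these two changes cannot be separated. Going by these compounds, how an unsubstituted phenyl, a single methoxy group, a pyridine ring or a dimethylamino group would compare at this place remains open.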